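The source may hold more compounds than are shown below. What is called first, only, known or untested is meant among the compounds shown, and "the series" means these compounds.

Three compounds sharing one core have numbers in a functional assay on B16-F0 cells (Mus musculus) for inhibition, read by CCK-8 assay, with a stated time of 48 h; a higher number here means a weaker inhibitor, a lower number a stronger inhibitor. Compound 1 `COc1cc(-c2ccnc3cc(-c4ccc(F)cc4)nn23)cc(OC)c1OC`, which carries a 4-fluorophenyl group, gives 4540 nM. Compound 2 `COc1cc(-c2ccnc3cc(-c4c[nH]c5ccccc45)nn23)cc(OC)c1OC`, with 1H-indol-3-yl at the same place, gives 40 nM, and compound 3 `COc1cc(-c2ccnc3cc(-c4ccc5c(ccn5C)c4)nn23)cc(OC)c1OC`, with 1-methyl-1H-indol-5-yl, gives 48 nM. Compound 3 thus stands level with compound 2, since a 1.2-fold higher number from compound 2 to compound 3 (0.08 log units; within the scatter) lies within the scatter, and far from compound 1.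

The next compound, compound 4 `COc1cc(-c2ccnc3cc(-c4ccc(C(F)(F)F)cc4)nn23)cc(OC)c1OC`, has 4-(trifluoromethyl)phenyl in place of 1-methyl-1H-indol-5-yl on an aromatic carbon.

For the measured compounds named here, two measured steps bear on this change. Both a 110-fold lower number from compound 1 to compound 2 (2.05 log units; beyond the scatter) and a 95-fold lower number from compound 1 to compound 3 (1.98 log units; beyond the scatter) are large, and both replace the 4-fluorophenyl group with an indolyl group. Compound 4 goes back to a phenyl group with one substituent, as in compound 1 at 4540 nM, so most of that large drop should be reversed. Going by the values given here, this rests on a single phenyl compound, and no measurement yet compares trifluoromethyl with fluorine here. A large step towards a higher number is therefore expected in this assay.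

The estimated change is an 83-fold higher number from compound 3 to compound 4 (1.92 log units; beyond the scatter). For compound 4 the expected value is 4000 nM, within an estimated range from 1200 nM to 14000 nM.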

Compound 4, half-maximal inhibitory concentration: 1770 nM
For compound 4 the middle estimate is 2.3-fold (0.35 log units) above the measured one; low and high end bracket the measured number.
By their numbers in this assay, from the lowest: compounds 2 and 3 (each within the scatter of the next); then compound 4; then compound 1.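

In this assay the gap between indolyl and phenyl groups at this position now rests on two phenyl compounds rather than one: the move away from 1-methyl-1H-indol-5-yl gives (a 37-fold higher number from compound 3 to compound 4 (1.57 log units; beyond the scatter)) and the move away from 1H-indol-3-yl gives (a 44-fold higher number from compound 2 to compound 4 (1.65 log units; beyond the scatter)). Within the phenyl pair, trifluoromethyl in place of fluoro gives a much smaller shift (a 2.6-fold lower number from compound 1 to compound 4 (0.41 log units; beyond the scatter)), so in these four compounds the change of substituent on the phenyl ring counts for far less than the change from an indolyl group to a phenyl group, although it still lies beyond the scatter. No measurement at hand accounts for either difference.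

Compounds 2 and 3 differ both in the attachment point of the indole and in the methyl group on its nitrogen, so the part played by each of these cannot be separated. An unsubstituted phenyl, a phenyl carrying an amine or a carboxylic acid, and a naphthyl group, which has two fused rings of carbon only, would show whether the second ring, its nitrogen or the phenyl substituent matters most here.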